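The source may report more compounds than this note shows. Statements on the series, on what has been measured and on what is new or still open speak of the compounds shown alone.

Series notes. Three analogues on the shared core are in hand. Compound 1 `COc1cccc2c1OCN(c1ccc3oc(-c4ccccc4)cc(=O)c3c1)C2` gives 17000 nM in a functional assay on MCF7 cells (Homo sapiens) for inhibition, read by MTT assay, with a stated time of 48 h; on this read-out higher numbers stand for weaker inhibition and lower numbers for stronger inhibition. Compound 2 `Cc1cccc2c1OCN(c1ccc3oc(-c4ccccc4)cc(=O)c3c1)C2` gives 14300 nM in this assay. Compound 3 `O=c1cc(-c2ccccc2)oc2ccc(N3COc4ccccc4C3)cc12` gives 27500 nM in this assay. For the measured compounds named here, the three numbers sit close together: a 1.2-fold lower number from compound 1 to compound 2 (0.08 log units; within the scatter), a 1.6-fold higher number from compound 1 to compound 3 (0.21 log units; within the scatter) and a 1.9-fold higher number from compound 2 to compound 3 (0.28 log units; within the scatter), each within the scatter, so no compound can be set apart from the others on these data. Compound 3 carries the highest number of the three, with compound 1 nearest and compound 2 furthest, but both gaps are within the scatter.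

Compound 4 `Cc1ccc2c(c1)CN(c1ccc3oc(-c4ccccc4)cc(=O)c3c1)CO2` has not been measured. It differs from compound 3 by methyl in place of hydrogen on an aromatic carbon. The step that bears on a methyl against hydrogen on this ring is a 1.9-fold higher number from compound 2 to compound 3 (0.28 log units; within the scatter), within the scatter, though that step concerns a methyl at another carbon of the ring; the methoxy exchange a 1.6-fold higher number from compound 1 to compound 3 (0.21 log units; within the scatter) was likewise within the scatter. No step beyond the scatter is therefore expected in this assay. For compound 4 the estimate is 22000 nM with a range of 9000 nM to 55000 nM. That estimate means an expected step of a 1.3-fold lower number from compound 3 to compound 4 (0.10 log units; within the scatter).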

Compound 4, half-maximal inhibitory concentration: 29800 nM
The estimate for compound 4 lay 1.4-fold (0.13 log units) below the measured number; low and high end bracket the measured number.
By their numbers in this assay, from the lowest: compounds 2, 1, 3 and 4 (each within the scatter of the next, the first and the last beyond it).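

In this assay, for the compounds shown here, methyl in place of hydrogen on this aromatic carbon, meta to a fused ring and para to a fused ring, gives a 1.1-fold higher number from compound 3 to compound 4 (0.03 log units; within the scatter), the first direct reading at this position, and it shows no effect beyond the scatter. The earlier methyl step concerned another carbon of the ring, and the two methyl compounds, compound 2 at 14300 nM and compound 4 at 29800 nM, lie beyond the scatter of each other, so where the methyl sits may matter, although this rests on a single pair. Nothing available explains this small step or that gap.

The compounds shown leave open whether an amine, a carboxylic acid or a longer chain on this carbon would move the number beyond the scatter. They also leave open how methoxy at this carbon would read.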